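This account rests on a few compounds, and the source may have more. Where it says the series, first, only, none or still open, it means among the compounds named here.

Measured so far in a functional assay on PANC-1 cells (Homo sapiens) for antiproliferative activity, read by MTT assay, with a stated time of 48 h; on this read-out higher numbers stand for weaker inhibition and lower numbers for stronger inhibition:
- compound 1 `COc1ccc(-c2c(Nc3cc(OC)c(OC)c(OC)c3)c3ccccc3oc2=O)cc1`: 77600 nM
- compound 2 `COc1ccc(-c2c(Nc3ccc(C)c(O)c3)c3ccccc3oc2=O)cc1`: 9750 nM
- compound 3 `COc1ccc(-c2c(Nc3ccc(C)cc3)c3ccccc3oc2=O)cc1`: 66100 nM

Compound 3 lies within the scatter of compound 1, and compound 2 gives a clearly lower number than either. Compound 4 `COc1ccc(-c2c(Nc3cccc(C(F)(F)F)c3)c3ccccc3oc2=O)cc1` differs from compound 3 in one place: 3-(trifluoromethyl)phenyl in place of 4-methylphenyl on a nitrogen on an aromatic ring. Among the compounds with values here, the one measured step, a 6.8-fold higher number from compound 2 to compound 3 (0.83 log units; beyond the scatter), removes a hydroxy, a different change, so it offers only indirect guidance. Compound 4 has no hydroxy, and neither does compound 1, which gives 77600 nM. No change beyond the scatter is therefore expected, and the estimated step is a 1.3-fold lower number from compound 3 to compound 4 (0.12 log units; within the scatter). The estimate for compound 4 is 50000 nM, with an expected range of 15000 nM to 120000 nM.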

Compound 4, half-maximal inhibitory concentration: 49100 nM
Beside the measured number, compound 4's estimate is 1.0-fold (0.01 log units) above it; low and high end bracket the measured number.
By their numbers in this assay, from the lowest: compound 2; then compounds 4, 3 and 1 (each within the scatter of the next).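

In this assay, 3-(trifluoromethyl)phenyl in place of 4-methylphenyl on the nitrogen gives a step within the scatter (a 1.3-fold lower number from compound 3 to compound 4 (0.13 log units; within the scatter)), so a ring with more heavy atoms and a different substituent leaves the number here unchanged. Compound 2 still stands apart from this new group (a 5.0-fold higher number from compound 2 to compound 4 (0.70 log units; beyond the scatter)), so among these compounds only the hydroxy-bearing ring gives a clearly lower number. Nothing measured here explains either step. Still open, going by these compounds, is whether an amine or a carboxylic acid in place of that hydroxy would give a similar number.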